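A few compounds are considered here, and "the series" means these few. Any claim that something is new, unique, unknown or untested is made for them only; others in the source may bear on it.

Measured compounds:
compound 1, `COc1cc(NC(C)CCCNC(=O)NCc2ccccc2)c2ncccc2c1`: 35000 nM
compound 2, `COc1cc(NC(C)CCCNC(=O)NC2CCCCC2)c2ncccc2c1`: > 100000 nM

In an ADME assay on WI-38 cells (Homo sapiens), read by MTT assay, with a stated time of 72 h (on this read-out lower numbers stand for stronger inhibition and higher numbers for weaker inhibition), compound 1 gives 35000 nM. Compound 2 reaches only a limit of this assay, > 100000 nM, so for compound 2 no number is known, only that it sits at the limit of > 100000 nM in this assay, at which 1 of the 2 values shown sits. Within the data shown here, the single measured step, an at least 2.8-fold higher number from compound 1 to compound 2 (0.45 log units; beyond the scatter), already moved the read-out to that limit. Compound 3, `COc1cc(NC(C)CCCNC(=O)N(C2CCCCC2)C2CCCCC2)c2ncccc2c1`, is the next step: cyclohexyl in place of hydrogen on an amide-type nitrogen, so that the urea nitrogen now carries two cyclohexyl groups. Among the measured compounds shown here, no measured pair shows the effect of adding a second cyclohexyl, and the only step in hand points toward weaker inhibition. The expectation for compound 3 is therefore a number at or beyond the limit, a step that the limit leaves unreadable from compound 2 to compound 3, with no sign of a gain. The estimate for compound 3 in this assay is 150000 nM, in a range from 60000 nM to 400000 nM, most probably reported again only as a limit.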

Compound 3, half-maximal inhibitory concentration: 18000 nM
Compound 3: the middle estimate sits 8.3-fold (0.92 log units) above what was measured; the whole stated range lies above it.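

In this assay, putting a second cyclohexyl on the urea nitrogen gives an at least 5.5-fold lower number from compound 2 to compound 3 (0.74 log units; beyond the scatter). This nitrogen can therefore carry a second large group, replacing the amide hydrogen, and the read-out moves toward stronger inhibition, the opposite direction to the earlier swap of benzyl for cyclohexyl. The true size of the new step stays unknown, since compound 2 is recorded only as a limit of the assay: the limit of > 100000 nM in this assay, at which 1 of the 3 values shown sits.

These compounds cannot tell whether the shift depends on the added cyclohexyl ring itself or simply on the amide hydrogen being gone. A small methyl group on the same nitrogen, or a second benzyl on the benzyl urea, would help separate those two readings.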